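The source may hold more compounds than are shown below. What is called first, only, known or untested is meant among the compounds shown, and "the series" means these compounds.

Compound 1 `COC(=O)c1c(-c2cc3ccccc3oc2=O)nn(-c2ccccc2)c1C(=O)OC` carries two methyl esters on the shared core and a plain phenyl on the ring nitrogen. In a functional assay on A549 cells (Homo sapiens) for cytotoxicity, read by MTT assay, with a stated time of 48 h (a lower number here means a stronger inhibitor, a higher number a weaker inhibitor), compound 1 gives 28000 nM. Among the three measured compounds it sits at the low end: the gap to compound 2 lies within the scatter, the gap to compound 3 beyond it.

Compound 2 `CCOC(=O)c1c(-c2cc3ccccc3oc2=O)nn(-c2cccc(C)c2)c1C(=O)OCC` has ethyl esters and a 3-methylphenyl group; in this assay compound 2 gives 52000 nM. Compound 3 `CCOC(=O)c1c(-c2cc3ccccc3oc2=O)nn(-c2ccc(OC)cc2)c1C(=O)OCC` has the same ethyl esters with a 4-methoxyphenyl group, and in this assay compound 3 gives 86000 nM. Among the measured compounds shown here, the one single-point step that has been measured, a 1.7-fold higher number from compound 2 to compound 3 (0.22 log units; within the scatter), shows that swapping one small group on this phenyl ring for another barely moved the number.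

Compound 4 `COC(=O)c1c(-c2cc3ccccc3oc2=O)nn(-c2cccc(F)c2)c1C(=O)OC` differs from compound 1 by fluoro in place of hydrogen on an aromatic carbon. For the measured compounds named here, no measured step matches this exact change; the nearest guide is the step from compound 2 to compound 3, which stayed within the scatter, and the values of compound 1 and compound 2, which also lie within the scatter of each other. The expected step, a 1.3-fold higher number from compound 1 to compound 4 (0.10 log units; within the scatter), is therefore small. Compound 4 is expected to give 35000 nM, within a range from 15000 nM to 90000 nM.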

Compound 4, half-maximal inhibitory concentration: 50000 nM
Beside the measured number, compound 4's estimate is 1.4-fold (0.15 log units) below it; measured number inside the range.
By their numbers in this assay, from the lowest: compounds 1, 4, 2 and 3 (each within the scatter of the next, the first and the last beyond it).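

Replacing hydrogen with fluoro on the phenyl of compound 1, the change from phenyl to 3-fluorophenyl, tests an unsubstituted ring directly. In this assay the result is a 1.8-fold higher number from compound 1 to compound 4 (0.25 log units; within the scatter), so adding fluoro on this aromatic carbon, meta to a large group, does not move the number beyond the usual variation between repeated measurements. The earlier step, a 1.7-fold higher number from compound 2 to compound 3 (0.22 log units; within the scatter), compared two substituted rings in compounds with ethyl esters, whereas this one starts from hydrogen in a compound with methyl esters, and both steps stay within the scatter; the data shown offer no independent measurement that could explain this outcome.

As far as these compounds go, with only these two steps on the phenyl ring, it remains open whether a group of a different kind there, such as an amine, a carboxylic acid or a longer chain, would produce a step beyond the scatter. The contribution of the esters also remains open, since no pair shown differs only in methyl versus ethyl esters.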